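Thiazolyl alkyne: methoxy to trifluoromethoxy on the phenyl ring

The compounds below may be only part of what the source reports. "The series", "measured", "known", "first", "only" and "open" are said of these compounds alone.

Compound 1, `COc1cccc(C#Cc2csc(C)n2)c1`: 49 nM
Compound 2, `Cc1nc(C#Cc2ccccc2F)cs1`: 140 nM

Both compounds were tested in a functional assay on CHO cells for agonist activity at metabotropic glutamate receptor 5 (Homo sapiens), read by inositol phosphate accumulation; a lower number here means a stronger inhibitor, a higher number a weaker inhibitor. Compound 1 gives 49 nM, the lowest of the two values; compound 2 gives 140 nM, a gap that lies beyond the usual scatter of the assay. Going by the values given here, no step between these two compounds involves a single change, so nothing beyond their two values can be read from the pair.

Compound 3, `Cc1nc(C#Cc2cccc(OC(F)(F)F)c2)cs1`, has not yet been measured in this assay. It is derived from compound 1 by one change: trifluoromethyl in place of methyl on an oxygen on an aromatic ring. Among the compounds with values here, no measured pair in this set shows what such a change does, so the step can only be guessed from the value of compound 1 alone.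

The account expects the step of a 1.6-fold higher number from compound 1 to compound 3 (0.21 log units; within the scatter) to be small, most likely a slight rise in the number, but not clearly beyond the scatter. Compound 3 is estimated at 80 nM, within a range from 25 nM to 250 nM.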

Compound 3, half-maximal inhibitory concentration: 266 nM
Compound 3: middle estimate off by 3.3-fold (0.52 log units), on the low side; measured number above the stated range.
By their numbers in this assay, from the lowest: compound 1; then compounds 2 and 3 (each within the scatter of the next).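

In this assay, putting trifluoromethyl in place of methyl on an oxygen on an aromatic ring gives a 5.4-fold higher number from compound 1 to compound 3 (0.73 log units; beyond the scatter) and so weakens the compound. Going by these compounds alone, this is the first single-change step in the set, and it shows that trifluoromethoxy cannot stand in for methoxy at this place on the core of compound 1 without a cost beyond the scatter. No measurement on hand accounts for this rise.

The compounds shown give only this one step at this place, so they do not tell whether the rise belongs to the three fluorines or to the larger group as a whole. On these data alone, an ethoxy, a difluoromethoxy or a hydroxyl at the same place could separate these readings, and whether the change would cost as much on another core also stays open.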